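Dropping the Methyl from Compound 1

The compounds below may be only part of what the source reports. "The series", "measured", "known", "first", "only" and "open" are said of these compounds alone.

Of the compounds shown here, three have been measured in an assay on CHO cells for displacement of a labelled ligand from prostaglandin D2 receptor 2 (Homo sapiens), read by scintillation counting; on this read-out lower numbers stand for stronger inhibition and higher numbers for weaker inhibition. Compound 1 `CCCS(=O)(=O)c1ccc(C)c(C#Cc2cc(C#N)ccc2OCC(=O)O)c1` gives 7 nM. Compound 2 `CN(C)C(=O)c1cccc(C#Cc2cc(Cl)ccc2OCC(=O)O)c1` gives 52 nM, and compound 3 `CC(C)S(=O)(=O)c1ccc(Cl)c(C#Cc2cc(Cl)ccc2OCC(=O)O)c1` gives 2.9 nM. Among these three numbers compound 1 stands second highest: compound 3 sits below it by a margin beyond the usual scatter, and compound 2 sits above it by a larger margin, also beyond the scatter.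

Compound 4 `CCCS(=O)(=O)c1cccc(C#Cc2cc(C#N)ccc2OCC(=O)O)c1` has not yet been measured. It differs from compound 1 in one place: hydrogen in place of methyl on an aromatic carbon. Going by the values given here, no pair of measured compounds differs by only this change, so the size of its effect is not known from the data at hand. Compound 2 also carries hydrogen at this place and gives a weaker number, but it differs from compound 1 elsewhere too, so its value cannot be read as the effect of the methyl alone. A modest weakening is expected, a 2.1-fold higher number from compound 1 to compound 4 (0.33 log units; beyond the scatter), though a step within the scatter would not be surprising. Compound 4 is estimated at 15 nM in this assay, with a range from 5 nM to 45 nM.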

Compound 4, inhibition constant: 21 nM
For compound 4 the middle estimate is 1.4-fold (0.15 log units) below the measured one, within the range that was stated.
By their numbers in this assay, from the lowest: compound 3; then compound 1; then compound 4; then compound 2.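

Going by these compounds alone, compound 1 and compound 4 form the first pair here that differs in one place only, so the effect of this methyl can now be read directly. In this assay, hydrogen in place of methyl on this aromatic carbon, ortho to a large group and para to a propylsulfonyl group, gives a 3.0-fold higher number from compound 1 to compound 4 (0.48 log units; beyond the scatter), showing that this single carbon makes a modest but real difference to the number. Nothing available explains why the change has this effect.

On these data alone, it remains open whether an ethyl or a methoxy group on this carbon would give a lower or a higher number than methyl. As far as these compounds go, it is also open whether the same change would have a step of similar size in a compound carrying chlorine in place of the nitrile.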